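Swapping the phenyl on a thiazole-acetic acid antagonist

The source may hold more compounds than are shown below. What is called first, only, known or untested is meant among the compounds shown, and "the series" means these compounds.

Measured compounds:
- compound 1, `Cc1nc(-c2ccc(Cl)cc2)c(CC(=O)O)s1`, 41000 nM in an in vitro functional assay on HEK285-7 cells for antagonist activity at prostaglandin D2 receptor 2 (Homo sapiens), read by BRET and beta-arrestin recruitment; on this read-out lower numbers stand for stronger inhibition and higher numbers for weaker inhibition
- compound 2, `O=C(O)Cc1sc(NC(=O)c2ccccc2)nc1-c1ccc(Cl)cc1`, 870 nM
- compound 3, `O=C(O)Cc1sc(C(c2ccc(F)cc2)c2ccc(F)cc2)nc1-c1ccccc1`, 240 nM

All three share a five-membered aromatic core carrying a carboxymethyl group, and they differ in what hangs from the remaining ring carbons. Compound 3 has the lowest number of the three; the gap to compound 2 and the much larger gap to compound 1 are both beyond the usual scatter, so compound 3 is the strongest inhibitor among the measured compounds.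

Compound 4, `N#Cc1cc(-c2nc(C(c3ccc(F)cc3)c3ccc(F)cc3)sc2CC(=O)O)ccc1F`, has not been measured. It differs from compound 3 in one place: 3-cyano-4-fluorophenyl in place of phenyl on an aromatic carbon. Going by the values given here, no measured pair shows this exact change, so its effect is not known from the data. The expectation is a small step, if any, likely toward a somewhat lower number, in line with the estimate of a 1.6-fold lower number from compound 3 to compound 4 (0.20 log units; within the scatter). Compound 4 is therefore expected to give about 150 nM, within a range from 40 nM to 600 nM.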

Compound 4, half-maximal inhibitory concentration: 520 nM
The estimate for compound 4 lay 3.5-fold (0.54 log units) below the measured number; the measured number falls inside the stated range.
By their numbers in this assay, from the lowest: compound 3; then compounds 4 and 2 (each within the scatter of the next); then compound 1.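

Going by these compounds alone, putting 3-cyano-4-fluorophenyl in place of phenyl on the aromatic carbon next to the ring nitrogen gives a 2.2-fold higher number from compound 3 to compound 4 (0.34 log units; beyond the scatter) in this assay, the first reading of a single change at this position. The step is modest but real: inhibition weakens and is not lost, so this position accepts a phenyl carrying both a nitrile and a fluorine, at a small cost. Nothing in the available data accounts for this loss.

The nitrile and the fluorine enter together, so the compounds shown cannot say whether one of them or the pair produces the step. Also open, going by these compounds, is how this position would respond to a phenyl bearing a methoxy group, or to a pyridine ring in place of the phenyl.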